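A few compounds are considered here, and "the series" means these few. Any claim that something is new, unique, unknown or untested is made for them only; others in the source may bear on it.

Cytotoxicity across the series is followed in an ADME assay on MDBK cells (Bos taurus) for cytotoxicity, read by MTT assay, with a stated time of 96 h; a lower number here means that less compound is tolerated, a higher number that more compound is tolerated. Of the compounds shown here, three carry numbers so far. Compound 1 `Fc1ccc(F)c(/N=N/Nc2ccccc2)c1` gives only a limit of the assay in this assay, > 100000 nM; that value sits at the limit of > 100000 nM in this assay, at which 1 of the 3 values shown sits. Compound 2 `CN(C)CCCN(/N=N/c1cc(F)ccc1F)c1ccccc1` gives 25000 nM in this assay. Compound 3 `CN(C)CCCN(/N=N/c1ccccc1)c1cccc(C(F)(F)F)c1` gives 38000 nM in this assay.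

Compound 2 and compound 1 differ in one place, (hydrogen in place of 3-(dimethylamino)propyl on a nitrogen on an aromatic ring), and the step that goes with this change is an at least 4.0-fold higher number from compound 2 to compound 1 (0.60 log units; beyond the scatter). Among the measured compounds shown here, this is the only measured step in the set. The values of compound 2 and compound 3 lie within the usual scatter of each other, so nothing is read from their spacing. The difference between the core of compound 2 and the core of compound 3 is not broken down here.

Compound 4 `FC(F)(F)c1cccc(N/N=N/c2ccccc2)c1` has not been measured in this assay. It stands to compound 3 as compound 1 stands to compound 2: hydrogen in place of 3-(dimethylamino)propyl on a nitrogen on an aromatic ring, the same change on the same kind of place, the surroundings matching word for word. With a single measured instance, the expectation rests entirely on the change having moved an at least 4.0-fold higher number from compound 2 to compound 1 (0.60 log units; beyond the scatter). The step expected is therefore a 3.9-fold higher number from compound 3 to compound 4 (0.60 log units; beyond the scatter), which would carry the value past the same limit. For compound 4 the estimate is 150000 nM. For compound 4 the expected range runs from 60000 nM to 400000 nM, with a real chance that this assay again returns only a limit.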

Compound 4, half-maximal cytotoxic concentration: > 100000 nM
Compound 4 was reported as a limit; the forecaster's own chance of this, stated with the estimate: 65%; the middle value does not contradict the limit.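

In this assay, hydrogen in place of 3-(dimethylamino)propyl on the nitrogen gives an at least 2.6-fold higher number from compound 3 to compound 4 (0.42 log units; beyond the scatter), so the change points the same way on both cores, and compound 4 ends at a limit of the assay, not at a number. Set side by side, the two instances read: the same change on two cores in this assay, an at least 4.0-fold higher number (0.60 log units; beyond the scatter) from compound 2 to compound 1 and an at least 2.6-fold higher number (0.42 log units; beyond the scatter) from compound 3 to compound 4; the limit leaves it open whether they differ This supports carrying the direction of the change from one of these cores to the other, but it gives no true size for the step on either core and no ranking of the two cores, and the limit also restricts what the set as a whole can show: the limit of > 100000 nM in this assay, at which 2 of the 4 values shown sit.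

The compounds shown leave open whether the higher number follows from losing the whole 3-(dimethylamino)propyl chain or only its dimethylamino group, a question that a plain propyl chain, a shorter or longer chain with the same amine, or a chain ending in a carboxylic acid could address. Also open, from the compounds shown here alone, is whether the same direction holds on further cores, and a core bearing a nitrile or a methoxy group would extend the comparison beyond these two pairs.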